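From compound 3 to compound 4: chloro gives way to fluoro

The source may report more compounds than this note shows. Statements on the series, on what has been measured and on what is new or still open speak of the compounds shown alone.

- compound 1 `COc1cc(-c2nc(-c3ccccc3)[nH]c2-c2ccnc(NCCCNS(=O)(=O)c3ccc(F)cc3)n2)ccc1F` gives 3960 nM
- compound 2 `O=S(=O)(NCCCNc1nccc(-c2[nH]c(-c3ccccc3)nc2-c2ccc(F)c(O)c2)n1)c1ccc(F)cc1` gives 19200 nM
- compound 3 `O=S(=O)(NCCCNc1nccc(-c2[nH]c(-c3ccccc3)nc2-c2ccc(Cl)c(O)c2)n1)c1ccc(Cl)cc1` gives 61300 nM

In a functional assay on LOX IMVI cells (Homo sapiens) for cytotoxicity, read by MTT assay, with a stated time of 24 h (on this read-out lower numbers stand for stronger inhibition and higher numbers for weaker inhibition), compound 3 (61300 nM) has the highest of the three numbers, beyond the scatter from both others. Compound 4 `O=S(=O)(NCCCNc1nccc(-c2[nH]c(-c3ccccc3)nc2-c2ccc(Cl)c(O)c2)n1)c1ccc(F)cc1` differs from compound 3 by fluoro in place of chloro on an aromatic carbon. Among the compounds with values here, the only measured step, a 4.8-fold higher number from compound 1 to compound 2 (0.69 log units; beyond the scatter), concerns another change and offers no direct guide to this one. Compound 2 (19200 nM) already carries the (4-fluorophenyl)sulfonyl group, so a modestly lower number is expected, possibly within the scatter. The expected change is a 1.8-fold lower number from compound 3 to compound 4 (0.26 log units; within the scatter) in this assay. For compound 4 the estimated value is 34000 nM, with an expected range of 15000 nM to 70000 nM.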

Compound 4, half-maximal inhibitory concentration: 2300 nM
The estimate for compound 4 lay 15-fold (1.17 log units) above the measured number; the whole stated range lies above it.
By their numbers in this assay, from the lowest: compounds 4 and 1 (each within the scatter of the next); then compound 2; then compound 3.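

In this assay, the (4-chlorophenyl)sulfonyl to (4-fluorophenyl)sulfonyl exchange gave a 27-fold lower number from compound 3 to compound 4 (1.43 log units; beyond the scatter) as a large step, so this position responds strongly to the halogen. The same two halogens exchanged on the other aryl ring gave an 8.3-fold lower number from compound 2 to compound 4 (0.92 log units; beyond the scatter) with chloro entering, so there the lower number goes with chloro, not fluoro. The exchange also brought the series back level with its methoxy member, with a 1.7-fold lower number from compound 1 to compound 4 (0.24 log units; within the scatter) lying within the scatter.

Nothing shown explains these steps. As far as these compounds go, whether a bromo, a methyl or a hydrogen at this position would hold the low number remains open.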